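One Methyl Group Added at the Outer Ring

A few compounds are considered here, and "the series" means these few. Any claim that something is new, unique, unknown or untested is made for them only; others in the source may bear on it.

Of the compounds shown here, two from this study have so far been tested in a functional assay on aorta for antagonist activity at Alpha-1D adrenergic receptor (Rattus norvegicus); on this read-out higher numbers stand for weaker binding and lower numbers for tighter binding. Compound 1, `COc1ccccc1N1CCN(CCCNc2nc(C)cc(C)c2C(N)=O)CC1`, gives 39.8 nM. Compound 2, `CN(C)C(=O)c1cccnc1NCCCN1CCN(c2ccccc2)CC1`, gives 15.9 nM. Of these two numbers compound 2 stands lowest; its nearest neighbour is compound 1, whose number is higher by a margin that lies beyond the usual scatter. The two compounds differ in several places at once, so no single step can be read off between them.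

Compound 3, `Cc1ccccc1N1CCN(CCCNc2ncccc2C(=O)N(C)C)CC1`, has not yet been measured. It differs from compound 2 in one place only: methyl in place of hydrogen on an aromatic carbon. Seen one bond further out, a phenyl becomes a 2-methylphenyl. Within the data shown here, no measured pair shows what a methyl in this place does on its own; compound 1 carries a different group there, but together with other changes. A small step is therefore expected in this assay, in either direction, not clearly beyond the scatter. The number for compound 3 is estimated at 20 nM, with a range from 6 nM to 60 nM, which means an expected step of a 1.3-fold higher number from compound 2 to compound 3 (0.10 log units; within the scatter).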

Compound 3, dissociation constant: 10 nM
The estimate for compound 3 lay 2.0-fold (0.30 log units) above the measured number, and the stated range covers the measured number.
By their numbers in this assay, from the lowest: compounds 3 and 2 (each within the scatter of the next); then compound 1.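

Among these compounds, until now, no pair of compounds isolated what a methyl does on this phenyl, and compound 2 with compound 3 is the first to do so. In this assay, turning the phenyl into a 2-methylphenyl, with the methyl on an aromatic carbon ortho to a large group, gives a 1.6-fold lower number from compound 2 to compound 3 (0.20 log units; within the scatter), so the two compounds cannot be told apart and this position accepts one added carbon without a change that can be distinguished from ordinary repeat-to-repeat variation. Nothing available here offers an explanation for the size of this step.

From the compounds shown here alone, a single methyl says nothing yet about other groups at this place, so it remains open whether a chlorine atom, a hydroxyl group or a longer chain such as propyl would also stay within the scatter of compound 2. Among the compounds shown here, the different group carried there by compound 1 cannot be judged on its own, since that compound also differs from compound 2 and compound 3 elsewhere, and no step involving it can be read.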